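Two imidazolium oximes and a methyl step measured in lipophilicity

A few compounds are considered here, and "the series" means these few. Any claim that something is new, unique, unknown or untested is made for them only; others in the source may bear on it.

Compound 1, `CC[n+]1ccn(CCN(C)C)c1/C=N/O`, and compound 2, `CCC[n+]1ccn(CCN(C)C)c1/C=N/O`, share one core and differ in a single spot: methyl in place of hydrogen on a saturated chain carbon, two bonds along the chain from an aromatic nitrogen. In a physicochemical assay for lipophilicity (a higher number here means a more lipophilic compound, a lower number a more polar compound), compound 1 gives -2.71, and compound 2 gives -2.73, so the step of a number 0.02 log units lower from compound 1 to compound 2 (within the scatter) is essentially nothing. Compound 3, `CN(CCCn1cc[n+](C)c1/C=N/O)S(C)(=O)=O`, is built on a different core; the difference between the two cores is not broken down here. In this assay compound 3 gives -2.63, a number that sits within the scatter of both compound 1 and compound 2.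

Compound 4, `CCN(CCCn1cc[n+](C)c1/C=N/O)S(C)(=O)=O`, is not yet measured. It differs from compound 3 as follows: methyl in place of hydrogen on a saturated chain carbon bound to a sulfonamide nitrogen. This is the same kind of change as that from compound 1 to compound 2, though not at the same place: in the earlier pair the carbon carrying the new methyl lies two bonds along the chain from an aromatic nitrogen, whereas in compound 4 it is bound to a sulfonamide nitrogen.

The expectation for compound 4 rests on the earlier pair, whose step a number 0.02 log units lower from compound 1 to compound 2 (within the scatter) stayed within the scatter. Because of that step, the step of a number 0.08 log units higher from compound 3 to compound 4 (within the scatter) is expected to be small as well. Accordingly, compound 4 is estimated to give -2.55 in this assay, with a plausible range from -2.9 to -2.2.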

Compound 4, distribution coefficient: -2.69
The estimate for compound 4 lay 0.14 log units above the measured number; the measured number falls inside the stated range.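

In this assay the added methyl gives a number 0.06 log units lower from compound 3 to compound 4 (within the scatter) and, on the core of compound 1, it gives a number 0.02 log units lower from compound 1 to compound 2 (within the scatter); on both cores shown, the change leaves the number within the scatter. This agreement rests on two pairs and on two different places, one a saturated chain carbon bound to a sulfonamide nitrogen and the other a saturated chain carbon two bonds along the chain from an aromatic nitrogen, and it does not show that the change would stay this small on any other core or at any other place in the series, nor does it give the change a direction. Nothing available here bears on why these steps are of this size.

The compounds shown leave open whether a larger group at the carbon bound to a sulfonamide nitrogen, such as a butyl chain or a carboxylic acid, would also stay within the scatter. They also leave open how the methyl change would read on a core carrying neither the sulfonamide nor the dimethylamine chain.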